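Swapping a Pyridine for a Pyrimidine on a Piperazine

The compounds below may be only part of what the source reports. "The series", "measured", "known", "first", "only" and "open" are said of these compounds alone.

The measured compounds and their values in a functional assay on MGC-803 cells (Homo sapiens) for antiproliferative activity, read by CCK-8 assay, with a stated time of 72 h, tested at 2 uM; on this read-out lower numbers stand for a weaker effect and higher numbers for a stronger effect at the one concentration tested:
Compound 1, `Nc1ccccc1NC(=O)c1ccc(CSC(=S)N2CCN(c3cccnc3)CC2)cc1`, gives 27.6%.
Compound 2, `Nc1ccccc1NC(=O)c1ccc(CSC(=S)N2CCc3cc(Cl)ccc32)cc1`, gives 57.7%.
Compound 3, `CCN(Cc1ccncc1)C(=S)SCc1ccc(C(=O)Nc2ccccc2N)cc1`, gives 71.6%.

Among these three, compound 1 stands lowest: compound 2 sits higher by a gap beyond the scatter, and compound 3 sits higher still, also beyond the scatter. Among the measured compounds shown here, the one single-point step that the measured compounds allow, a number 13.9 percentage points higher from compound 2 to compound 3 (beyond the scatter), concerns the group on the thiocarbonyl carbon, not the part of the molecule that changes here.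

Compound 4, `Nc1ccccc1NC(=O)c1ccc(CSC(=S)N2CCN(c3ncccn3)CC2)cc1`, differs from compound 1 in one place: pyrimidin-2-yl in place of pyridin-3-yl on an amine nitrogen in a ring. For the measured compounds named here, no measured pair isolates this kind of exchange, so the data give no direct guide to its size or direction. The change keeps the same ring size and the same attachment to the amine nitrogen in the ring, so a small step, not beyond the scatter, is the most defensible expectation.

Compound 4 is therefore expected to give 30% in this assay, within a range of 12% to 52%. The step this estimate implies, a number 2.4 percentage points higher from compound 1 to compound 4 (within the scatter), is expected to stay within the usual scatter.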

Compound 4, a percentage reported as inhibition, at one concentration (the size of the read-out at that concentration, not a potency): 28.4%
For compound 4 the middle estimate is 1.6 percentage points above the measured one, and the stated range covers the measured number.
By their numbers in this assay, from the lowest: compounds 1 and 4 (each within the scatter of the next); then compound 2; then compound 3.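

In this assay, pyrimidin-2-yl in place of pyridin-3-yl on an amine nitrogen in a ring gives a number 0.8 percentage points higher from compound 1 to compound 4 (within the scatter), so this pair cannot be told apart at the one concentration tested. Among the compounds shown here, this is the first direct look at this position: the earlier step concerned a different exchange on the thiocarbonyl carbon, whereas here an aromatic ring with 1 hetero atom gives way to one with 2 hetero atoms, and the read-out shows no difference beyond the scatter. No measurement at hand explains this result or shows what the ring contributes to the effect on the cells.

Both groups shown at this position are six-membered aromatic rings containing nitrogen, so it remains open whether a plain phenyl ring, a methyl group or an acetyl group on the same nitrogen would read the same way. A single concentration also gives no potency, so this one pair cannot show whether the two compounds would still match across a range of concentrations.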